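The source may report more compounds than this note shows. Statements on the series, on what has been measured and on what is new or still open speak of the compounds shown alone.

Measured in a functional assay on the whole organism (artery, strain albino) with Rattus norvegicus as the target, with a stated time of 900 min, at a dose of 10 mg/kg by the oral route; a lower number here means less inhibition, a higher number more inhibition at the dose given (going by the name of the read-out):

compound 1 `COc1ccc(C2N=C(SCc3cccc(Cl)c3)NC(C)=C2C(=O)Nc2ccc(F)cc2)cc1OC`: 13.3%
compound 2 `CC1=C(C(=O)Nc2ccc(F)cc2)C(c2ccc([N+](=O)[O-])cc2)N=C(SCc2ccccc2)N1`: 21%
compound 3 `CC1=C(C(=O)Nc2ccc(F)cc2)C(c2ccc([N+](=O)[O-])cc2)N=C(SCc2ccccc2Cl)N1`: 11.3%

Compound 3 gives the lowest of these three numbers, yet both compound 1 and compound 2 sit within the usual scatter of it, so the three cannot be told apart. Compound 4 `CC1=C(C(=O)Nc2ccc(F)cc2)C(c2ccc([N+](=O)[O-])cc2)N=C(SCc2cccc(Cl)c2)N1` differs from compound 3 by 3-chlorophenyl in place of 2-chlorophenyl on a saturated chain carbon bound to a sulfur. For the measured compounds named here, the one single-point step available, a number 9.7 percentage points lower from compound 2 to compound 3 (within the scatter), added the chloro and stayed within the scatter. Compound 1 already carries the (3-chlorobenzyl)sulfanyl group, on a different core, and its number lies close to that of compound 3. The step of a number 2.7 percentage points higher from compound 3 to compound 4 (within the scatter) in this assay is therefore expected to stay within the scatter. Compound 4 is estimated at 14%, between 5% and 25%.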

Compound 4, a percentage reported as inhibition, in the whole organism at one dose (the size of the read-out at that dose, not a potency): 10.8%
Estimate against measurement, compound 4: 3.2 percentage points above, within the range that was stated.
By their numbers in this assay, from the lowest: compounds 4, 3, 1 and 2 (each within the scatter of the next, the first and the last beyond it).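

Placing the chloro differently on the benzyl group in this assay gives a number 0.5 percentage points lower from compound 3 to compound 4 (within the scatter), so 2-chlorophenyl and 3-chlorophenyl cannot be told apart at this position. Against the chlorine-free benzyl group, the 3-chloro version gives a number 10.2 percentage points lower from compound 2 to compound 4 (beyond the scatter), a modest step that, unlike the 2-chloro one, clears the scatter. With the (3-chlorobenzyl)sulfanyl group held constant, the ring-carbon change gives a number 2.5 percentage points lower from compound 1 to compound 4 (within the scatter), so 4-nitrophenyl and 3,4-dimethoxyphenyl cannot be separated either.

No measured evidence here explains these numbers. From the compounds shown here alone, whether an amine or a carboxylic acid in place of the chloro, or a longer chain in place of the benzyl group, would move the number remains open.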